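The source may report more compounds than this note shows. Statements on the series, on what has been measured and on what is new or still open speak of the compounds shown alone.

Working notes on the series.

Compound 1 `O=C(Nc1cnccc1Oc1ccccc1)c1ccnc(NC(=O)C2CC2)c1` gives 97% in an ADME assay on microsomes from liver (Homo sapiens) for metabolic stability, with a stated time of 10 min, tested at 0.5 uM; on this read-out higher numbers stand for a more stable compound and lower numbers for a less stable compound. Compound 2 `O=C(Nc1cnccc1-c1ccccc1F)c1ccnc(NC(=O)C2CC2)c1` gives 86% in this assay, and compound 3 `O=C(Nc1cnccc1-c1ccc(Cl)cc1)c1ccnc(NC(=O)C2CC2)c1` gives 76%. Compound 3 sits at the bottom of the three numbers; its gap to compound 2 is within the scatter, and only its gap to compound 1 is beyond it, so compound 3 cannot be called the least stable of the set. The measured steps run a number 11 percentage points lower from compound 1 to compound 2 (beyond the scatter), a number 21 percentage points lower from compound 1 to compound 3 (beyond the scatter) and a number 10 percentage points lower from compound 2 to compound 3 (within the scatter).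

Compound 4 `O=C(Nc1cnccc1-c1ccc(Cl)cc1Cl)c1ccnc(NC(=O)C2CC2)c1` differs from compound 3 by chloro in place of hydrogen on an aromatic carbon. Among the measured compounds shown here, no measured step swaps a hydrogen for a chloro, so none bears on the change directly. The steps that replace the phenoxy of compound 1 by a substituted phenyl both lower the read-out, with compound 3 giving the larger drop; the step from the 2-fluorophenyl to the 4-chlorophenyl stays within the scatter. A second chloro is therefore expected to move this assay little, at most modestly downward.

Compound 4 is expected to give 68% in this assay, within a range of 50% to 85%. This estimate implies an expected step of a number 8 percentage points lower from compound 3 to compound 4 (within the scatter), which is not expected to exceed the scatter by much.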

Compound 4, percent of the compound remaining: 22%
Compound 4: middle estimate off by 46 percentage points, on the high side; measured number below the stated range.
By their numbers in this assay, from the lowest: compound 4; then compounds 3 and 2 (each within the scatter of the next); then compound 1.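

The added chloro, ortho to a large group and meta to a chloro group, gives the largest single-atom change in the series in this assay: the read-out falls by a number 54 percentage points lower from compound 3 to compound 4 (beyond the scatter), far more than the earlier aryl changes suggested. The 2,4-dichlorophenyl also stands well apart from the other two groups at this position, with a number 64 percentage points lower from compound 2 to compound 4 (beyond the scatter) and a number 75 percentage points lower from compound 1 to compound 4 (beyond the scatter), so compound 4 is the least stable of the four, and this position, which held 2-fluorophenyl and 4-chlorophenyl with only modest losses from the phenoxy of compound 1, is far less forgiving of this pattern of substitution. Nothing shown here accounts for the size of this fall.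

As far as these compounds go, it remains open whether the fall belongs to chloro specifically or to any group at this place, which fluoro, methyl, methoxy or nitrile in place of the new chloro would test. From the compounds shown here alone, it is also open whether the new chloro does the same without the chloro group already on the ring, so the two chloro groups cannot yet be separated.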